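A few compounds are considered here, and "the series" means these few. Any claim that something is new, unique, unknown or untested is made for them only; others in the source may bear on it.

Measured so far:
- compound 1 (`O=C(NCCCNc1cc(-c2cn(-c3ccccc3)nc2-c2cccc(O)c2)ccn1)Nc1ccc(F)cc1`) gives 7540 nM in a functional assay on UACC-257 cells (Homo sapiens) for antiproliferative activity, read by sulforhodamine B assay, with a stated time of 48 h; on this read-out lower numbers stand for stronger inhibition of growth and higher numbers for weaker inhibition of growth
- compound 2 (`O=C(NCCCNc1cc(-c2cn(-c3ccccc3)nc2-c2cccc(O)c2)ccn1)Nc1cccc(C(F)(F)F)c1`) gives 10100 nM in this assay

Going by the values given here, the single measured step, a 1.3-fold higher number from compound 1 to compound 2 (0.13 log units; within the scatter), places compound 1 within the scatter of its only neighbour. Compound 3 (`COc1cccc(-c2nn(-c3ccccc3)cc2-c2ccnc(NCCCNC(=O)Nc3ccc(F)cc3)c2)c1`) changes another part of compound 1: methyl in place of hydrogen on an oxygen on an aromatic ring, hydroxy to methoxy. That measured step concerns the aryl group on the amide-type nitrogen, so no measurement bears directly on this oxygen. On these data alone, no step beyond the scatter is therefore expected in this assay, and the direction stays open. The estimated step is a 1.2-fold higher number from compound 1 to compound 3 (0.08 log units; within the scatter), a small one. Compound 3 is expected at 9000 nM, with an estimated range of 4000 nM to 20000 nM.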

Compound 3, concentration for total growth inhibition: 16900 nM
Estimate against measurement, compound 3: 1.9-fold (0.27 log units) below; measured number inside the range.
By their numbers in this assay, from the lowest: compounds 1, 2 and 3 (each within the scatter of the next, the first and the last beyond it).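

In this assay the oxygen of the 3-hydroxyphenyl group gives the first response beyond the scatter in this series, with hydroxy to methoxy producing a 2.2-fold higher number from compound 1 to compound 3 (0.35 log units; beyond the scatter) as a modest loss of growth inhibition. The aryl change on the amide-type nitrogen, by contrast, gave a 1.3-fold higher number from compound 1 to compound 2 (0.13 log units; within the scatter) and so stayed within the scatter. No measurement at hand explains the difference between hydroxy and methoxy.

On these data alone, whether the loss follows the missing hydrogen or the added methyl remains open. An amine or fluorine at this place, or a longer ethoxy group, could separate the two.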